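This account rests on a few compounds, and the source may have more. Where it says the series, first, only, none or still open, it means among the compounds named here.

Working notes on the aryl amide series. Compound 3 `CNc1nc(Nc2ccc(C)c(N)c2)ncc1C(=O)Nc1cc(NC(=O)c2cc(OC)c(OC)c(OC)c2)ccc1C` gives 250 nM in a functional assay on K562 cells (Homo sapiens) for antiproliferative activity, read by CellTiter-Glo and CCK-8 assay, with a stated time of 72 h (a lower number here means a stronger inhibitor of growth, a higher number a weaker inhibitor of growth), the highest of the three numbers recorded so far. Compound 2 `CNc1nc(Nc2ccc(C)c(N)c2)ncc1C(=O)Nc1cc(NC(=O)c2cc(OC)cc(OC)c2)ccc1C` gives 230 nM in this assay, and the step of a 1.1-fold higher number from compound 2 to compound 3 (0.04 log units; within the scatter) places the two within the scatter. Compound 1 `CNc1nc(Nc2ccc(C)c(N)c2)ncc1C(=O)Nc1cc(NC(=O)c2cccc(C(F)(F)F)c2)ccc1C` gives 14 nM in this assay; the steps of a 16-fold higher number from compound 1 to compound 2 (1.22 log units; beyond the scatter) and an 18-fold higher number from compound 1 to compound 3 (1.25 log units; beyond the scatter) are the only large moves in the set.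

Compound 4 `CNc1nc(Nc2ccc(C)c(N)c2)ncc1C(=O)Nc1cc(NC(=O)c2ccc3c(c2)OCCO3)ccc1C` is not yet measured. The change is 2,3-dihydro-1,4-benzodioxin-6-yl in place of 3,4,5-trimethoxyphenyl on a carbonyl carbon. Among the measured compounds shown here, two measured steps bear on it: a 1.1-fold higher number from compound 2 to compound 3 (0.04 log units; within the scatter), showing that adding a methoxy to this aryl ring moves the number little, and an 18-fold higher number from compound 1 to compound 3 (1.25 log units; beyond the scatter), showing that exchanging the whole aryl group for the trifluoromethyl-bearing one changes it greatly. The entering group still carries oxygen acceptors on an aromatic ring, as the change shows, so the expected step of a 1.4-fold lower number from compound 3 to compound 4 (0.14 log units; within the scatter) is small, probably within the scatter and leaning slightly lower. The estimate for compound 4 is 180 nM, with a range from 70 nM to 450 nM.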

Compound 4, concentration for 50% growth inhibition: 320 nM
Compound 4: middle estimate off by 1.8-fold (0.25 log units), on the low side; measured number inside the range.
By their numbers in this assay, from the lowest: compound 1; then compounds 2, 3 and 4 (each within the scatter of the next).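

With a 1.3-fold higher number from compound 3 to compound 4 (0.11 log units; within the scatter) and a 1.4-fold higher number from compound 2 to compound 4 (0.14 log units; within the scatter), the 2,3-dihydro-1,4-benzodioxin-6-yl group, whose oxygens sit in a six-membered non-aromatic ring, reads in this assay like the open methoxy groups of 3,5-dimethoxyphenyl and 3,4,5-trimethoxyphenyl. Tying the oxygens into a ring therefore gives no separation at this carbonyl carbon among the compounds shown. Among the compounds shown here, the large gap to the trifluoromethyl-bearing aryl group also holds for this third oxygen-bearing group, with a 23-fold higher number from compound 1 to compound 4 (1.36 log units; beyond the scatter) on the same scale as the earlier steps from compound 1.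

The compounds shown leave open whether the low number of compound 1 depends on trifluoromethyl itself, or would also appear with chloro or a nitrile in its place. The effect of a basic amine such as a piperazine on this aryl ring is equally open, and no measurement given here explains these results.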